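Hydroxy to Amino Repeated on a Second Core

The source may hold more compounds than are shown below. What is called first, only, known or untested is meant among the compounds shown, and "the series" means these compounds.

Compound 1 `COc1ccc(-c2cc3ccccc3c(-c3cccc(O)c3)n2)cc1` gives 1200 nM in a functional assay on HCT-15 cells (Homo sapiens) for cytotoxicity, read by CCK-8 assay and cell counting, with a stated time of 72 h; a higher number here means a weaker inhibitor, a lower number a stronger inhibitor. Its partner compound 2 `COc1ccc(-c2cc3ccccc3c(-c3cccc(N)c3)n2)cc1` gives 2350 nM in this assay. The change between them is amino in place of hydroxy on an aromatic carbon and it made a step of a 2.0-fold higher number from compound 1 to compound 2 (0.29 log units; within the scatter). Compound 3 `COc1ccc(-c2cc3cc(C)ccc3c(-c3cccc(O)c3)n2)c(C)c1` gives 1750 nM in this assay; how its core differs from that of compound 1 is not broken down here. The values of compound 3 and compound 2 lie within the scatter of each other, as do those of compound 3 and compound 1.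

Compound 4 `COc1ccc(-c2cc3cc(C)ccc3c(-c3cccc(N)c3)n2)c(C)c1` has not yet been measured. It differs from compound 3 by amino in place of hydroxy on an aromatic carbon, the same change as that from compound 1 to compound 2, at the same kind of place. Because the earlier step was a 2.0-fold higher number from compound 1 to compound 2 (0.29 log units; within the scatter), the step from compound 3 to compound 4 is expected to be a 2.0-fold higher number from compound 3 to compound 4 (0.30 log units; within the scatter), a small step that may itself fall within the scatter. Compound 4 is therefore estimated to give 3500 nM in this assay, with an expected range from 1800 nM to 7000 nM.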

Compound 4, half-maximal inhibitory concentration: 2770 nM
Estimate against measurement, compound 4: 1.3-fold (0.10 log units) above, within the range that was stated.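

In this assay the change from 3-hydroxyphenyl to 3-aminophenyl on the second core gave a 1.6-fold higher number from compound 3 to compound 4 (0.20 log units; within the scatter) and so carried over from the core of compound 1 to the core of compound 3 with no difference in step size that the data can resolve: the same change on two cores in this assay, a 2.0-fold higher number (0.29 log units; within the scatter) from compound 1 to compound 2 and a 1.6-fold higher number (0.20 log units; within the scatter) from compound 3 to compound 4, 1.2-fold (0.09 log units) apart, within the scatter of two such steps. Each of the two steps lies within the scatter on its own, so the pair shows that the swap behaves alike on these two cores, but it does not establish a real difference between the hydroxy and amino compounds on either core. Two cores are also too few to say that the same would hold across the wider series.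

The compounds shown leave open whether other groups at this place, such as a carboxylic acid, a methoxy group or a longer aminoalkyl chain, would give a step beyond the scatter. They also leave open whether the swap would behave the same way on a core carrying a halogen or an amine instead of the methyl groups of compound 3.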